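The compounds below may be only part of what the source reports. "The series", "measured", "known", "first", "only" and "open" are said of these compounds alone.

Of the compounds shown here, two in this set have been tested in an ADME assay on SW480 cells (Homo sapiens) for cytotoxicity, read by MTT assay, with a stated time of 72 h (on this read-out lower numbers stand for stronger inhibition and higher numbers for weaker inhibition), and a third still awaits its turn. Compound 1, `CCCCCN1C(=O)C/C(=C\c2cccc(C(=O)Nc3cccc(F)c3)c2)C1=O`, gives in this assay a result of > 100000 nM, which is a limit of the measurement rather than a number. Compound 2, `COc1ccc(NC(=O)c2cccc(/C=C3\CC(=O)N(c4ccccc4)C3=O)c2)c(C)c1`, likewise gives in this assay a result of > 100000 nM, again a limit and not a number. So compound 2 stands exactly where every value in this set stands: the limit of > 100000 nM in this assay, at which 2 of the 2 values shown sit.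

Compound 3, `CSc1cccc(NC(=O)c2cccc(/C=C3\CC(=O)N(c4ccccc4)C3=O)c2)c1`, is the untested partner of compound 2. The difference between the two is 3-(methylsulfanyl)phenyl in place of 4-methoxy-2-methylphenyl on an amide-type nitrogen. No step between two measured compounds has been shown here, so there is nothing measured to say how a change of this kind moves the read-out. With both known values resting at the limit, the expected step of a number no higher from compound 2 to compound 3 (the limit leaves the size open) is none beyond the usual scatter. Compound 3 is therefore estimated to give 100000 nM in this assay, with a range from 40000 nM to 300000 nM, and it is most likely to return only a limit as well.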

Compound 3, half-maximal inhibitory concentration: 74300 nM
Compound 3: the middle estimate sits 1.3-fold (0.13 log units) above what was measured; the range from low to high includes it.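

In this assay, among the compounds shown here, compound 3 gives 74300 nM, the first true number in this set, which shows that with 3-(methylsulfanyl)phenyl on the amide-type nitrogen the read-out can fall inside the measurable range. Replacing 4-methoxy-2-methylphenyl with this group gives an at least 1.3-fold lower number from compound 2 to compound 3 (0.12 log units; that floor lies within the scatter), and that figure is only a floor, not the size of the change itself. The real step could be much larger or could be no more than ordinary scatter, because the starting point is a limit and not a number: the limit of > 100000 nM in this assay, at which 2 of the 3 values shown sit.

The two groups differ in more than one feature, with sulfur in place of oxygen, a missing methyl group and a different arrangement on the ring, and the compounds shown do not separate these features, so it remains open which of them matters. Also open, from the compounds shown here alone, is how the read-out would respond to a plain unsubstituted phenyl, or to an amine or a carboxylic acid on that ring, in this assay.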